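Chloro for Cyclohexyl on the Tetrahydronaphthalene-Type Core

The source may hold more compounds than are shown below. What is called first, only, known or untested is meant among the compounds shown, and "the series" means these compounds.

Of the compounds shown here, three have been measured in an assay on isolated protein for binding affinity to Alpha-1A adrenergic receptor (Rattus norvegicus), read by radioligand binding; on this read-out higher numbers stand for weaker inhibition and lower numbers for stronger inhibition. Compound 1 `CCS(=O)(=O)Nc1cc(C2CCCCC2)cc2c1CCCC2c1c[nH]cn1` gives 269 nM. Compound 2 `CCCS(=O)(=O)Nc1cccc2c1CCCC2c1c[nH]cn1` gives 1700 nM. Compound 3 `CCS(=O)(=O)Nc1cccc(S(=O)(=O)c2c[nH]cn2)c1` reaches only the limit of the assay, < 10000 nM, which is a boundary rather than a number. Among the two numbers shown, compound 1 stands lowest, with compound 2 nearest at a gap beyond the usual scatter; one further value is the limit noted as the limit of < 10000 nM in this assay, at which 1 of the 3 values shown sits.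

Compound 4 `CCS(=O)(=O)Nc1cc(Cl)cc2c1CCCC2c1c[nH]cn1` has not yet been measured. It differs from compound 1 in one place: chloro in place of cyclohexyl on an aromatic carbon. Going by the values given here, no step between two measured compounds isolates this kind of exchange, so the expectation rests on the spread of the numbers seen so far. The author expects the step of a 3.0-fold higher number from compound 1 to compound 4 (0.47 log units; beyond the scatter) to run toward a higher number, beyond the scatter, since compound 2, which lacks any group at that position and carries a propylsulfonylamino group instead, gives 1700 nM. Compound 4 is therefore estimated at 800 nM, within a range of 250 nM to 2500 nM.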

Compound 4, inhibition constant: 45.7 nM
The estimate for compound 4 lay 18-fold (1.24 log units) above the measured number, and the stated range ends above it.
By their numbers in this assay, from the lowest: compound 4; then compound 1; then compound 2.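

Going by these compounds alone, at this aromatic carbon, meta to the (ethylsulfonyl)amino group and para to a fused ring, the exchange of cyclohexyl for chloro gives a 5.9-fold lower number from compound 1 to compound 4 (0.77 log units; beyond the scatter) in this assay and so provides the first one-place comparison at this position. The six-carbon ring is therefore not required here for a low number, and a single chlorine atom on the same core reads lower than cyclohexyl, beyond the usual scatter. The one limit shown belongs to a compound outside this exchange and gives no cause for the step.

The compounds shown leave open how a methyl, a methoxy or an amine on this carbon would read. They also leave open how much of the step belongs to the arrival of chloro and how much to the loss of cyclohexyl.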